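Phenyl for benzofuranyl on a nucleoside scaffold: expected outcome

This account rests on a few compounds, and the source may have more. Where it says the series, first, only, none or still open, it means among the compounds named here.

Three compounds sharing a fused bicyclic core carrying a sugar have been tested in a functional assay on HCT-116 cells (Homo sapiens), read by MTT assay, with a stated time of 72 h; on this read-out higher numbers stand for weaker inhibition and lower numbers for stronger inhibition. Compound 3 `COc1ncnc2c1c(-c1cc3ccccc3o1)cn2[C@@H]1O[C@H](CO)[C@@H](O)[C@H]1O` gives 14500 nM in this assay. Compound 1 `COc1ncnc2c1c(-c1ccccc1)cn2[C@@H]1O[C@H](CO)[C@@H](O)[C@H]1O` carries the same core but differs by phenyl in place of 1-benzofuran-2-yl on an aromatic carbon. For compound 1 only a limit of the assay is known, > 20000 nM in this assay. The measured step is therefore an at least 1.3-fold higher number from compound 3 to compound 1 (0.13 log units; that floor lies within the scatter), and it reaches (the limit of > 20000 nM in this assay, at which 2 of the 3 values shown sit).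

Compound 2 `O=c1[nH]cnc2c1c(-c1cc3ccccc3o1)cn2[C@@H]1O[C@H](CO)[C@@H](O)[C@H]1O` has a different core; the difference between the two cores is not broken down here. For compound 2, too, only a limit is known, > 20000 nM in this assay.

Compound 4 `O=c1[nH]cnc2c1c(-c1ccccc1)cn2[C@@H]1O[C@H](CO)[C@@H](O)[C@H]1O` stands to compound 2 as compound 1 stands to compound 3, the same change at the same place: phenyl in place of 1-benzofuran-2-yl on an aromatic carbon. Since compound 2 already sits at the limit and the same change from compound 3 to compound 1 gave an at least 1.3-fold higher number from compound 3 to compound 1 (0.13 log units; that floor lies within the scatter), compound 4 is expected to remain at or beyond that limit. The step expected is a step that the limit leaves unreadable from compound 2 to compound 4. Compound 4 is estimated at 40000 nM in this assay, most likely reported only as a limit, with a range from 20000 nM to 120000 nM.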

Compound 4, half-maximal inhibitory concentration: > 20000 nM
Compound 4: a limit, no number (the forecaster's own chance of this, stated with the estimate: 90%); the middle value does not contradict the limit.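

In this assay compound 4 gives > 20000 nM, which is a limit of the assay and not a number. Compound 2 also has only a limit, so no step can be read between compound 2 and compound 4. The compounds shown leave open how far compounds 1, 2 and 4 lie beyond that limit, and whether the change from benzofuranyl to phenyl has a similar size on both cores: the limit of > 20000 nM in this assay, at which 3 of the 4 values shown sit.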